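This account rests on a few compounds, and the source may have more. Where it says the series, first, only, none or still open, it means among the compounds named here.

Series notes, chain-extended citrate analogues carrying a thioether-linked aryl chain. Three compounds carry numbers in an assay on isolated protein for inhibition of ATP-citrate synthase (Rattus norvegicus); a higher number here means a weaker inhibitor, a lower number a stronger inhibitor. Compound 1 `O=C(O)CC(O)(CSCCCCCCc1ccccc1Cl)C(=O)O` gives 69000 nM. Compound 2 `O=C(O)CC(O)(CSCCCCCCc1cccc(Cl)c1)C(=O)O` gives 150000 nM. Compound 3 `O=C(O)CC(O)(CSCCCCCc1ccccc1)C(=O)O` gives 490000 nM, the highest of the three numbers; its nearest neighbour is compound 2, a 3.3-fold higher number from compound 2 to compound 3 (0.51 log units; beyond the scatter), and its furthest is compound 1, a 7.1-fold higher number from compound 1 to compound 3 (0.85 log units; beyond the scatter). The two chloro-substituted compounds also differ from one another, a 2.2-fold higher number from compound 1 to compound 2 (0.34 log units; beyond the scatter).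

Compound 4 `O=C(O)CC(O)(CSCCCCCCc1ccc(F)cc1)C(=O)O` has not yet been measured. The change from compound 3 is 4-fluorobenzyl in place of phenyl on a saturated chain carbon, five bonds along the chain from a sulfur. For the measured compounds named here, the steps that bear on it are the two that run in the opposite sense, from a chlorobenzyl to a bare phenyl at the same place: a 7.1-fold higher number from compound 1 to compound 3 (0.85 log units; beyond the scatter) and a 3.3-fold higher number from compound 2 to compound 3 (0.51 log units; beyond the scatter), both modest and both beyond the scatter. Reversing that direction, a halobenzyl entering in place of phenyl, should therefore lower the number in this assay. Going by the values given here, no fluorine-bearing compound has been measured, so the size is taken from the chloro pair and widened accordingly; the expected step is a 3.1-fold lower number from compound 3 to compound 4 (0.49 log units; beyond the scatter). Compound 4 is estimated at 160000 nM, within a range of 60000 nM to 400000 nM.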

Compound 4, inhibition constant: 120000 nM
Estimate against measurement, compound 4: 1.3-fold (0.12 log units) above; the measured number falls inside the stated range.
By their numbers in this assay, from the lowest: compounds 1, 4 and 2 (each within the scatter of the next, the first and the last beyond it); then compound 3.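

In this assay, 4-fluorobenzyl in place of phenyl on a saturated chain carbon, five bonds along the chain from a sulfur, gives a 4.1-fold lower number from compound 3 to compound 4 (0.61 log units; beyond the scatter) and so extends the picture from the two chlorobenzyl groups to a fluorine-bearing benzyl, with all three halobenzyl compounds showing lower numbers than compound 3. Among the halogenated compounds, the 4-fluorophenyl group of compound 4 shows a 1.3-fold lower number from compound 2 to compound 4 (0.10 log units; within the scatter) and a 1.7-fold higher number from compound 1 to compound 4 (0.24 log units; within the scatter), both within the scatter, so compound 4 cannot be separated from either chloro compound, even though those two lie apart at a 2.2-fold higher number from compound 1 to compound 2 (0.34 log units; beyond the scatter) in the same assay. Nothing measured here explains the step from compound 3 to compound 4 or the closeness of the halogenated compounds.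

As far as these compounds go, the change from phenyl to 4-fluorobenzyl brings in both a chain methylene and a fluorine, so the share of each in the step stays open, and a plain benzyl at this place would be needed to divide it. From the compounds shown here alone, how far this position tolerates a carboxylic acid or an amine on the ring, or a longer chain, also remains open.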